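The source may hold more compounds than are shown below. What is called first, only, known or untested is meant among the compounds shown, and "the series" means these compounds.

Two compounds in this cytotoxicity series share one core. Compound 1 has the structure `O=C(/C=C/c1ccc([N+](=O)[O-])o1)c1ccc(F)cc1` and compound 2 the structure `O=C(/C=C/c1ccc([N+](=O)[O-])o1)c1cc2ccccc2oc1=O`. In a toxicity assay on Vero cells (Chlorocebus sabaeus) for cytotoxicity (a lower number here means that less compound is tolerated, a higher number that more compound is tolerated), compound 1 gives 463000 nM, and compound 2 gives 360000 nM. Compound 1 carries the nominally upper figure of the two, but the gap to compound 2 lies within the usual scatter of such measurements, so on this evidence the two cannot be told apart. Within the data shown here, no pair of measured compounds differs in only one place, so no single-step comparison is at hand to calibrate the change that follows.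

Compound 3, with the structure `O=C(/C=C/c1ccc([N+](=O)[O-])o1)c1ccc(OCc2ccc(F)cc2)cc1`, differs from compound 1 by (4-fluorobenzyl)oxy in place of fluoro on an aromatic carbon. Among the measured compounds shown here, there is no measured precedent for this change, so a shift beyond the scatter is not firmly expected, though a moderate move toward a lower tolerated concentration is judged somewhat more likely than a rise. The expected step is a 2.3-fold lower number from compound 1 to compound 3 (0.36 log units; beyond the scatter). For compound 3 in this assay, a value of 200000 nM is estimated, with a range from 70000 nM to 500000 nM.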

Compound 3, half-maximal cytotoxic concentration: 430000 nM
Compound 3: the middle estimate sits 2.2-fold (0.33 log units) below what was measured, within the range that was stated.
By their numbers in this assay, from the lowest: compounds 2, 3 and 1 (each within the scatter of the next).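

Among these compounds, the swap of fluoro for (4-fluorobenzyl)oxy on an aromatic carbon, para to a large group, gives a 1.1-fold lower number from compound 1 to compound 3 (0.03 log units; within the scatter) in this assay and provides the first single-place comparison. At this position, a group that brings in a further six-membered aromatic ring of carbon only and an added oxygen leaves compound 3 indistinguishable from compound 1, so in this one pair the much larger substituent has no effect that can be resolved from the scatter. No supporting measurement is available to explain why the two compounds cannot be told apart.

This single pair cannot show whether the position is generally permissive, since an amine, a carboxylic acid or a plain benzyloxy group could still behave differently in this assay from the two groups compared here. Among the compounds shown here, it also leaves open whether the same replacement would give a similarly small step on a different core, such as that of compound 2, where only one value is at hand.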